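The source may hold more compounds than are shown below. What is called first, only, known or untested is meant among the compounds shown, and "the series" means these compounds.

The series shares the core shown in compound 1, `Cc1cc2occ(-c3nc(-c4ccccc4)c(-c4ccccc4)n3-c3ccc(Cl)c(Cl)c3)c(=O)c2cc1Cl`; in an ADME assay on MCF-10A cells (Homo sapiens) for cytotoxicity, read by MTT assay, with a stated time of 72 h (a lower number here means a stronger inhibitor, a higher number a weaker inhibitor), compound 1 gives 98000 nM. Compound 2, `Cc1cc2occ(-c3nc(-c4ccccc4)c(-c4ccccc4)n3-c3cccc(Cl)c3)c(=O)c2cc1Cl`, belongs to the same set and in this assay compound 2 gives "not determined" (no result reported); compound 3, `Cc1ccc(-n2c(-c3coc4cc(C)c(Cl)cc4c3=O)nc(-c3ccccc3)c2-c2ccccc2)c(C)c1`, also belongs to the set and in this assay compound 3 gives "not determined" (no result reported), so compound 3 stands without a number, and one further entry in the set likewise lacks one. Compound 4, `Cc1cc2occ(-c3nc(-c4ccccc4)c(-c4ccccc4)n3-c3ccc([N+](=O)[O-])cc3)c(=O)c2cc1Cl`, is the next member. Compound 4 differs from compound 3 by 4-nitrophenyl in place of 2,4-dimethylphenyl on an aromatic nitrogen. Among the compounds with values here, only compound 1 carries a measured value in this assay, namely 98000 nM, so there is no measured step on which to size this change. Within the data shown here, the single reading for compound 1 points to weak cytotoxicity across the set, and the move from compound 3 to compound 4 is expected to stay within the usual scatter rather than shift the reading clearly in either direction. Compound 4 is therefore expected to give about 85000 nM in this assay, within a range of 30000 nM to 200000 nM.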

Compound 4, half-maximal inhibitory concentration: > 100000 nM
Compound 4 was reported as a limit; the forecaster's own chance of this, stated with the estimate: 30%; middle value at least 1.1-fold (0.07 log units) from the limit.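

In this assay compound 4 gives > 100000 nM, which is a limit of the assay and not a number. Placing 4-nitrophenyl in place of 3,4-dichlorophenyl on the aromatic nitrogen gives an at least 1.0-fold higher number from compound 1 to compound 4 (0.00 log units; that floor lies within the scatter), so this position now has one readable step, though it is only a floor and does not show a change beyond the scatter. Steps involving compound 2 or compound 3 cannot be read, and this limit is reached by only one compound in the set: the limit of > 100000 nM in this assay, at which 1 of the 4 values shown sits.

The compounds shown leave open how far the true value of compound 4 lies from its limit. They also leave open whether an amine or a carboxylic acid on the phenyl ring at this position, or a longer alkyl chain in its place, would give a clearly lower number in this assay.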